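Working notes: methoxy-for-hydrogen step on compound 2

The source may hold more compounds than are shown below. What is called first, only, known or untested is meant among the compounds shown, and "the series" means these compounds.

Measured so far:
Compound 1 `COc1ccc2nc(-c3c(O)cc(O)cc3O)c(=O)n(CC(=O)O)c2c1` gives 69.3% in a functional assay, with a stated time of 240 min, tested at 50 uM; on this read-out higher numbers stand for a stronger effect at the one concentration tested and lower numbers for a weaker effect.
Compound 2 `COc1ccc2nc(/C=C/c3ccc(O)cc3)c(=O)n(CC(=O)O)c2c1` gives 34.3% in this assay.

Compound 2 stands lowest of the two numbers in hand; the nearest, compound 1, lies above it by a gap beyond the usual scatter. For the measured compounds named here, no step between measured compounds that differ in one place is available, so nothing in the present numbers isolates the effect of a single substituent.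

The next compound is compound 3 `COc1ccc2nc(/C=C/c3ccc(O)c(OC)c3)c(=O)n(CC(=O)O)c2c1`. Compared with compound 2 it carries methoxy in place of hydrogen on an aromatic carbon. Going by the values given here, no measured pair shows this change, and the two values in hand give no direction for it. The expected step in this assay from compound 2 to compound 3 is therefore small, a number 3.7 percentage points higher from compound 2 to compound 3 (within the scatter), and not beyond the scatter in either direction. On that basis compound 3 is estimated at 38% in this assay, with a range from 20% to 58%; the width reflects the absence of any measured step of this kind.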

Compound 3, a percentage reported as activity, at one concentration (the size of the read-out at that concentration, not a potency): 65.9%
Estimate against measurement, compound 3: 27.9 percentage points below, and the stated range ends below it.
By their numbers in this assay, from the lowest: compound 2; then compounds 3 and 1 (each within the scatter of the next).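

In this assay, the series now has its first step between compounds that differ in one place: methoxy in place of hydrogen on the aromatic carbon ortho to the hydroxy group, taking 4-hydroxyphenyl to 4-hydroxy-3-methoxyphenyl, comes with a number 31.6 percentage points higher from compound 2 to compound 3 (beyond the scatter). Compound 1 and compound 2 differ in more than one place and could not show this, whereas this carbon now stands as a place where one added methoxy group changes the read-out by a large step at the one concentration tested, although this rests on a single pair. Nothing in hand speaks to the origin of this step.

Still open, as far as these compounds go, is whether the step belongs to methoxy itself or would also follow from another group on the same carbon, such as a free hydroxy, an ethoxy or a chlorine. Also open, from the compounds shown here alone, is whether the step depends on the hydroxy group ortho to it, which a comparison with an amine or a methoxy in that group's place would address.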